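Bromo for chloro on the acetamido ring: expected step

This account rests on a few compounds, and the source may have more. Where it says the series, first, only, none or still open, it means among the compounds named here.

Compound 1 `O=C(Nc1cccc(-c2nc(-c3ccc(NC(=O)c4cccnc4)cc3Cl)no2)c1)c1ccccc1` gives 12800 nM in a functional assay on MDA-MB-231 cells (Homo sapiens) for antiproliferative activity, read by MTT assay, with a stated time of 72 h; on this read-out lower numbers stand for stronger inhibition and higher numbers for weaker inhibition. Compound 2 `CC(=O)Nc1ccc(NC(=O)Nc2cccc(-c3nc(-c4ccc(NC(=O)c5cccnc5)cc4Cl)no3)c2)cc1Cl` returns only a limit, > 10000 nM, in this assay. The step that the limit leaves unreadable from compound 1 to compound 2 therefore cannot be sized, since the limit of > 10000 nM in this assay, at which 1 of the 2 values shown sits, is where compound 2 sits. Compound 3 `CC(=O)Nc1ccc(NC(=O)Nc2cccc(-c3nc(-c4ccc(NC(=O)c5cccnc5)cc4Cl)no3)c2)cc1Br` differs from compound 2 by bromo in place of chloro on an aromatic carbon. Among the compounds with values here, no measured step bears on this exchange, and compound 2 stands only at a limit. Compound 3 is expected to sit near that limit. The expected step is a step that the limit leaves unreadable from compound 2 to compound 3, not beyond the scatter. Compound 3 is estimated at 15000 nM, between 5000 nM and 50000 nM, most likely again only a limit.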

Compound 3, half-maximal inhibitory concentration: 1000 nM
Estimate against measurement, compound 3: 15-fold (1.18 log units) above; measured number below the stated range.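

In this assay this position, ortho to an acetamido group, responds to the halogen itself: bromo in place of chloro gives an at least 10-fold lower number from compound 2 to compound 3 (1.00 log units; beyond the scatter). With bromo, the exchange of phenyl on the carbonyl carbon for (4-acetamido-3-bromophenyl)amino can now be read, as a 13-fold lower number from compound 1 to compound 3 (1.11 log units; beyond the scatter), while its chloro counterpart cannot be read. Compound 2 is held only at a limit, so the size of the halogen step is bounded on one side only: the limit of > 10000 nM in this assay, at which 1 of the 3 values shown sits.

Open, on these data alone, is how iodo, fluoro or plain hydrogen would behave at this position. Also open, as far as these compounds go, is whether the bromo result holds with a longer acyl chain in place of the acetyl.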